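Compound 3 and the step to compound 4

The source may hold more compounds than are shown below. What is called first, only, known or untested is meant among the compounds shown, and "the series" means these compounds.

Compound 1 `O=C1c2c[n+]([O-])c3ccccc3c2C(=O)c2c1c1ccccc1n2Cc1cn([C@H]2O[C@H](CO)[C@@H](O)[C@H]2O)nn1` gives 1370 nM
Compound 2 `O=C1c2c[n+]([O-])c3ccccc3c2C(=O)c2c1c1ccccc1n2Cc1cn([C@@H]2C[C@H](O)[C@@H](CO)O2)nn1` gives 820 nM
Compound 3 `O=C1c2c[n+]([O-])c3ccccc3c2C(=O)c2c1c1ccccc1n2Cc1cn(CC(O)CO)nn1` gives 760 nM

In a toxicity assay on HEK-293T cells (Homo sapiens) for cytotoxicity, read by MTT assay, with a stated time of 72 h (a higher number here means a weaker inhibitor, a lower number a stronger inhibitor), compound 3 stands at 760 nM and cannot be separated from the other two compounds, as both steps that reach it lie within the scatter (a 1.1-fold lower number from compound 2 to compound 3 (0.03 log units; within the scatter)) and (a 1.8-fold lower number from compound 1 to compound 3 (0.26 log units; within the scatter)).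

Compound 4 `CC1(C)O[C@@H](CO)[C@H](Cn2cc(Cn3c4c(c5ccccc53)C(=O)c3c[n+]([O-])c5ccccc5c3C4=O)nn2)O1` has not yet been measured. It carries 5-(hydroxymethyl)-2,2-dimethyl-1,3-dioxolan-4-yl in place of 1,2-dihydroxyethyl on a saturated chain carbon bound to an aromatic nitrogen.

Among the compounds with values here, no measured compound carries this group, so the evidence is indirect. The two steps above exchange a 2,3-dihydroxypropyl group for oxolanyl groups on an aromatic nitrogen, and neither moves the number beyond the scatter. The loss of a hydroxy group on a saturated ring carbon also stays within it (a 1.7-fold lower number from compound 1 to compound 2 (0.22 log units; within the scatter)). These three compounds therefore offer no reason to expect a change of a particular direction in this assay, and no step beyond the scatter is expected (a 1.1-fold higher number from compound 3 to compound 4 (0.05 log units; within the scatter)). Compound 4 is estimated at 850 nM with an expected range from 400 nM to 1700 nM (an estimate only).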

Compound 4, half-maximal inhibitory concentration: 120 nM
Compound 4: middle estimate off by 7.1-fold (0.85 log units), on the high side; measured number outside the range, below it.
By their numbers in this assay, from the lowest: compound 4; then compounds 3, 2 and 1 (each within the scatter of the next).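

In this assay, within the data shown here, the group on the saturated chain carbon bound to an aromatic nitrogen proves able to shift the number: 5-(hydroxymethyl)-2,2-dimethyl-1,3-dioxolan-4-yl in place of 1,2-dihydroxyethyl gives the first change in this set to lie beyond the scatter (a 6.3-fold lower number from compound 3 to compound 4 (0.80 log units; beyond the scatter)). The comparisons with the two oxolanyl compounds point the same way (a 6.8-fold lower number from compound 2 to compound 4 (0.83 log units; beyond the scatter); an 11-fold lower number from compound 1 to compound 4 (1.06 log units; beyond the scatter)), so compound 4 separates from all three earlier compounds, which could not be told apart from one another. Nothing in the information available explains this shift.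

The change from compound 3 to compound 4 brings in the five-membered ring, its two methyl groups and two defined stereocentres together, so the compounds shown cannot say which of these features goes with the lower number. Also open, on these data alone, is whether the number would hold with the same ring lacking the two methyl groups, with the opposite stereocentres, or with an amine or a carboxylic acid in place of the hydroxymethyl group.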